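Removing One Methoxy Group: Effect on Cell Growth Inhibition

This account rests on a few compounds, and the source may have more. Where it says the series, first, only, none or still open, it means among the compounds named here.

Of the compounds shown here, three have been measured in a functional assay on MCF7 cells (Homo sapiens) for inhibition, read by sulforhodamine B assay, with a stated time of 72 h; a higher number here means a weaker inhibitor, a lower number a stronger inhibitor. Compound 1, `COc1cc(OC)c(C(=O)/C=C/c2cn(-c3ccccc3)nc2-c2cccnc2)c(OC)c1`, gives 1000 nM. Compound 2, `COc1ccc(C(=O)/C=C/c2cn(-c3ccccc3)nc2-c2cccnc2)c(OC)c1`, differs from it only by hydrogen in place of methoxy on an aromatic carbon. In this assay compound 2 gives 2300 nM; the step is a 2.3-fold higher number from compound 1 to compound 2 (0.36 log units; beyond the scatter). Compound 3, `COc1ccc(C(=O)/C=C/c2cn(-c3ccccc3)nc2-c2ccncc2)c(OC)c1OC`, is built from the same atoms as compound 1 joined differently; the difference between the two cores is not broken down here. In this assay compound 3 gives 3300 nM, within the scatter of compound 2 and beyond it relative to compound 1.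

Compound 4, `COc1ccc(C(=O)/C=C/c2cn(-c3ccccc3)nc2-c2ccncc2)cc1OC`, has not yet been measured. It differs from compound 3 by hydrogen in place of methoxy on an aromatic carbon. This is the same kind of change as that from compound 1 to compound 2, though the place differs: in compound 3 the leaving methoxy sits ortho to a methoxy group and meta to a methoxy group, whereas in compound 1 it sits meta to two methoxy groups. Because the earlier step was a 2.3-fold higher number from compound 1 to compound 2 (0.36 log units; beyond the scatter), a similar weakening is expected for compound 4, an expected step of a 2.0-fold higher number from compound 3 to compound 4 (0.29 log units; within the scatter). Compound 4 is estimated at 6500 nM, expected to lie between 2500 nM and 16000 nM.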

Compound 4, half-maximal inhibitory concentration: 4300 nM
Beside the measured number, compound 4's estimate is 1.5-fold (0.18 log units) above it, and the stated range covers the measured number.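

In this assay, replacing methoxy with hydrogen on the second core gives a 1.3-fold higher number from compound 3 to compound 4 (0.11 log units; within the scatter). Set beside the earlier step, the size of this change does not differ measurably between the two cores: the same change on two cores in this assay, a 2.3-fold higher number (0.36 log units; beyond the scatter) from compound 1 to compound 2 and a 1.3-fold higher number (0.11 log units; within the scatter) from compound 3 to compound 4, 1.8-fold (0.25 log units) apart, within the scatter of two such steps. Within the data shown here, this agrees with the change carrying over from one core to the other, but it rests on only two pairs of compounds, and the pairs differ both in the core and in where the methoxy group leaves the ring, so neither influence can be separated from the other; nor does it show that removing methoxy weakens compound 4, as only the first step lies beyond the scatter.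

The compounds shown leave open what a hydroxyl group, an ethoxy group or a fluorine atom would do in place of this methoxy group, as only methoxy and hydrogen appear there. As far as these compounds go, whether the step would keep its size on a third core also remains open.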